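The source may report more compounds than this note shows. Statements on the series, on what has been measured and on what is new or still open speak of the compounds shown alone.

Measured so far in an assay on HEK-293T cells for antagonist activity at vitamin D3 receptor (Homo sapiens), read by a luciferase reporter, with a stated time of 24 h; on this read-out higher numbers stand for weaker inhibition and lower numbers for stronger inhibition:
- compound 1 `CC(C)c1onc(-c2c(Cl)cccc2Cl)c1COc1ccc(-c2nc3cc(C(=O)O)ccc3n2C)cc1` gives 4410 nM
- compound 2 `CCCC(CCC)n1c(-c2ccc(OCc3c(-c4c(Cl)cccc4Cl)noc3C(C)C)cc2)nc2ccc(C(=O)O)cc21` gives > 10000 nM
- compound 3 `CC(C)c1onc(-c2c(Cl)cccc2Cl)c1COc1ccc(-c2nc3ccc(C(=O)O)cc3n2C)c(Cl)c1` gives 3520 nM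

Compound 1 and compound 3 both return numbers, and the two numbers lie within the usual scatter of each other, so no order between them is claimed. Compound 2, which carries 1-propylbutyl on the aromatic nitrogen of the shared core, is known only as a limit: the value recorded for compound 2 is the limit of > 10000 nM in this assay, at which 1 of the 3 values shown sits, a limit of this assay and not a number. On the values shown, compound 2 therefore stands at the weak end of the three, with the two methyl-bearing compounds giving measurable numbers and compound 2 giving none.

Compound 4 `CC(=O)N1CCC(n2c(-c3ccc(OCc4c(-c5c(Cl)cccc5Cl)noc4C(C)C)cc3)nc3ccc(C(=O)O)cc32)CC1` is not yet measured. It differs from compound 2 in one place: 1-acetylpiperidin-4-yl in place of 1-propylbutyl on an aromatic nitrogen. Going by the values given here, no measured pair isolates this change, so the size of the step cannot be read from the data, and because compound 2 sits at a limit, even a measurable number for compound 4 could not be sized against it with confidence. The expectation is that compound 4 returns a number rather than a limit, landing near compound 1. Compound 4 is estimated at 5000 nM, with a range from 1500 nM to 15000 nM, which corresponds to an expected step of an at least 2.0-fold lower number from compound 2 to compound 4 (0.30 log units; that floor lies within the scatter).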

Compound 4, half-maximal inhibitory concentration: > 10000 nM
Compound 4 ended at the assay's limit (the forecaster's own chance of this, stated with the estimate: 35%); middle value at least 2.0-fold (0.30 log units) from the limit.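

In this assay compound 4 gives > 10000 nM, a limit of the assay and not a number. Compound 2 also stands at a limit, so no step between compound 2 and compound 4 can be read: the limit of > 10000 nM in this assay, at which 2 of the 4 values shown sit.

The compounds shown leave open whether 1-acetylpiperidin-4-yl and 1-propylbutyl on an aromatic nitrogen differ at all in this assay.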